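Isopropyl to methyl on two weakly active fused cores

The compounds below may be only part of what the source reports. "The series", "measured", "known", "first", "only" and "open" are said of these compounds alone.

The set comprises compound 1 `C=CCn1ncc2c(C)nc(C(C)C)n2c1=O`, compound 2 `CC(C)c1ncn2c(O)nncc12`, compound 3 `C=CCn1ncc2c(C)nc(C)n2c1=O` and the unmeasured compound 4 `Cc1ncn2c(O)nncc12`. In a functional assay for inhibition, with Homo sapiens as the target (on this read-out higher numbers stand for weaker inhibition and lower numbers for stronger inhibition), compound 1 reaches only the assay limit, reported as > 48000 nM. Compound 2 likewise stands at the assay limit in this assay, given as > 48000 nM. Within the data shown here, compound 3 is the one compound with a number in this assay, giving 73000 nM. The change from compound 1 to compound 3 is methyl in place of isopropyl on an aromatic carbon, and the step that the limit leaves unreadable from compound 1 to compound 3 cannot be read because of the limit of > 48000 nM in this assay, at which 2 of the 3 values shown sit. How the core of compound 1 and the core of compound 2 differ is not broken down here. The change from compound 2 to compound 4 is methyl in place of isopropyl on an aromatic carbon; it is the same kind of change as that from compound 1 to compound 3, but the place differs, sitting next to the ring nitrogen and two ring bonds from the ring nitrogen rather than between two ring nitrogen atoms. With compound 2 standing only at the assay limit, the step from compound 2 to compound 4 is expected to be small, about a step that the limit leaves unreadable from compound 2 to compound 4. Compound 4 is therefore estimated at 70000 nM in this assay, between 30000 nM and 200000 nM.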

Compound 4, half-maximal inhibitory concentration: > 48000 nM
Compound 4: a limit, no number; the forecaster's own chance of this, stated with the estimate: 60%; the middle value is on the limit's open side.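

No step can be read from compound 2 to compound 4 in this assay, because both compounds stand only at a limit and neither has a number: the limit of > 48000 nM in this assay, at which 3 of the 4 values shown sit.

The compounds shown leave open whether methyl in place of isopropyl on an aromatic carbon shifts inhibition at all, in either the pair of compound 1 and compound 3 or the pair of compound 2 and compound 4.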